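Dropping a Methyl from a Compound at the Assay Limit

A few compounds are considered here, and "the series" means these few. Any claim that something is new, unique, unknown or untested is made for them only; others in the source may bear on it.

Measured compounds:
compound 1 `CNc1nncc2cncn12`: > 48000 nM
compound 2 `Cc1ncn2c(NCc3ccco3)nncc12`: > 48000 nM

In a functional assay for inhibition, with Homo sapiens as the target (a higher number here means a weaker inhibitor, a lower number a stronger inhibitor), compound 1 `CNc1nncc2cncn12` gives > 48000 nM, which is a limit of the assay rather than a number. In this assay compound 2 `Cc1ncn2c(NCc3ccco3)nncc12` gives > 48000 nM, again a limit and not a number. Compound 2 therefore stands at the edge of what the assay reports, a position described by the limit of > 48000 nM in this assay, at which 2 of the 2 values shown sit. Compound 3 `c1coc(CNc2nncc3cncn23)c1` differs from compound 2 in a single place: hydrogen in place of methyl on an aromatic carbon. Among the measured compounds shown here, no step between measured compounds is available to show how large such a change is. Given (the limit of > 48000 nM in this assay, at which 2 of the 2 values shown sit), the expected step that the limit leaves unreadable from compound 2 to compound 3 is none beyond the scatter, and the read-out is expected most likely to be a limit once more. Compound 3 is estimated at 60000 nM, in a range from 15000 nM to 250000 nM.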

Compound 3, half-maximal inhibitory concentration: > 48000 nM
Compound 3: no number, only a limit; the forecaster's own chance of this, stated with the estimate: 80%; the middle value lies beyond the limit too.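

In this assay compound 3 gives > 48000 nM, a limit and not a number. The steps from compound 1 and compound 2 to compound 3 therefore cannot be read. The compounds shown leave open whether the methyl or the furan-2-yl group changes the strength of inhibition at all.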